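Swapping the Aryl Group on the Amine Side Chain

This account rests on a few compounds, and the source may have more. Where it says the series, first, only, none or still open, it means among the compounds named here.

This account concerns a series sharing one core, in which the group on a saturated chain carbon bound to an amine nitrogen is varied. In a functional assay on BMMC cells (Mus musculus, strain C57BL/6) for inhibition, with stated times of 5 days and 48 h (on this read-out lower numbers stand for stronger inhibition and higher numbers for weaker inhibition), compound 1 `C=C1CC[C@@H]2[C@](C)(CNCc3ccc(Br)cc3)[C@H](O)CC[C@@]2(C)[C@@H]1/C=C/C1=CCOC1=O` gives 430 nM, while compound 2 `C=C1CC[C@@H]2[C@](C)(CNCc3cccs3)[C@H](O)CC[C@@]2(C)[C@@H]1/C=C/C1=CCOC1=O` gives 1070 nM. Among the compounds with values here, compound 2 therefore holds the highest of the two numbers so far, and the single measured step, a 2.5-fold higher number from compound 1 to compound 2 (0.40 log units; beyond the scatter), is a modest one arising from thiophen-2-yl in place of 4-bromophenyl.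

Compound 3 `C=C1CC[C@@H]2[C@](C)(CNCc3ccc4c(c3)CC=N4)[C@H](O)CC[C@@]2(C)[C@@H]1/C=C/C1=CCOC1=O` is not yet measured. Relative to compound 2 it carries a group of 9 heavy atoms (8 carbon, 1 nitrogen; one five-membered non-aromatic ring with 1 hetero atom, one six-membered aromatic ring of carbon only) in place of a group of 5 heavy atoms (4 carbon, 1 sulfur; one five-membered aromatic ring with 1 hetero atom), on a saturated chain carbon bound to an amine nitrogen. Within the data shown here, the only step that bears on this change is the one from compound 1 to compound 2, which shows that exchanging the group at this position shifts the number only modestly. The entering group is again an aromatic ring, so an expected step of similar size, a 1.8-fold lower number from compound 2 to compound 3 (0.25 log units; within the scatter), back toward the number of compound 1 seems reasonable. Compound 3 is accordingly expected to give 600 nM in this assay, within a range from 200 nM to 1800 nM.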

Compound 3, half-maximal inhibitory concentration: 550 nM
Compound 3: middle estimate off by 1.1-fold (0.04 log units), on the high side; low and high end bracket the measured number.
By their numbers in this assay, from the lowest: compounds 1, 3 and 2 (each within the scatter of the next, the first and the last beyond it).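

In this assay, the group of 9 heavy atoms, with one five-membered non-aromatic ring and one six-membered aromatic ring, cannot be told apart from thiophen-2-yl (a 1.9-fold lower number from compound 2 to compound 3 (0.29 log units; within the scatter)) or from 4-bromophenyl (a 1.3-fold higher number from compound 1 to compound 3 (0.11 log units; within the scatter)). Within the data shown here, compounds 1 and 2 alone showed only that exchanging one single-ring group for another at this place, on a saturated chain carbon bound to an amine nitrogen, can give a modest step beyond the scatter; compound 3 adds that a group with two rings can stand there with neither of its steps leaving the scatter, although it is the largest of the three groups by heavy atoms. Nothing in the available information explains these numbers or says what the entering group does in the cells.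

All three groups shown contain an aromatic ring, so it remains open how the number would respond to a group with no ring at all, such as a butyl chain, or to a saturated ring such as cyclohexyl. As far as these compounds go, it also remains open how a carboxylic acid or a second amine on the aromatic ring would read out in this assay and whether either would give a step beyond the scatter.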